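A few compounds are considered here, and "the series" means these few. Any claim that something is new, unique, unknown or untested is made for them only; others in the source may bear on it.

Working notes on the urea series. Two compounds have a number in a functional assay on HepG2 cells (Homo sapiens) for inhibition, read by MTT assay, with a stated time of 120 h; on this read-out higher numbers stand for weaker inhibition and lower numbers for stronger inhibition. Compound 1 `CC(NC(=O)C#Cc1ccc(NC(=O)Nc2cc(C(F)(F)F)ccc2Cl)cc1)c1ccccc1` gives 19000 nM in this assay, the higher of the two numbers and so the weaker of the pair. Compound 2 `O=C(/C=C/c1ccc(NC(=O)Nc2ccc(Cl)c(C(F)(F)F)c2)cc1)NC1CCC1` gives 7510 nM in this assay, and the gap between these two lies beyond the usual scatter; the two differ in several places at once, so what the gap shows cannot be tied to one change.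

Compound 3 `CC(NC(=O)C#Cc1ccc(NC(=O)Nc2ccc(Cl)c(C(F)(F)F)c2)cc1)c1ccccc1` is not yet measured. It differs from compound 1 in one place: 4-chloro-3-(trifluoromethyl)phenyl in place of 2-chloro-5-(trifluoromethyl)phenyl on an amide-type nitrogen. Within the data shown here, no pair of measured compounds differs only in this way, so the size of the step rests on judgement alone. The step from compound 1 to compound 3 is expected to be small, at most a modest move toward stronger inhibition, around a 1.7-fold lower number from compound 1 to compound 3 (0.24 log units; within the scatter). Compound 3 is therefore estimated at 11000 nM in this assay, with a range from 3500 nM to 35000 nM.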

Compound 3, half-maximal inhibitory concentration: 20500 nM
Compound 3: the middle estimate sits 1.9-fold (0.27 log units) below what was measured; low and high end bracket the measured number.
By their numbers in this assay, from the lowest: compound 2; then compounds 1 and 3 (each within the scatter of the next).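

In this assay, among these compounds, 4-chloro-3-(trifluoromethyl)phenyl in place of 2-chloro-5-(trifluoromethyl)phenyl on an amide-type nitrogen gives a 1.1-fold higher number from compound 1 to compound 3 (0.03 log units; within the scatter) as the first step that can be tied to one place. With the rest of the core of compound 1 held fixed, these two arrangements of the same atoms cannot be told apart on this read-out, so this exchange on the aryl group carried by that nitrogen leaves the number unchanged within the scatter. Nothing measured alongside these numbers speaks to the reason for this result.

Going by these compounds, whether a different group on this nitrogen, such as a pyridine ring or a phenyl ring bearing a carboxylic acid or an amine, would shift the number beyond the scatter stays open. Also open, on these data alone, is whether the same exchange gives a similar step on a core other than that of compound 1.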